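A few compounds are considered here, and "the series" means these few. Any claim that something is new, unique, unknown or untested is made for them only; others in the source may bear on it.

Measured in a functional assay on MDA-MB-231 cells (Homo sapiens) for inhibition, read by MTT assay, with stated times of 18 h and 4 h; on this read-out higher numbers stand for weaker inhibition and lower numbers for stronger inhibition:
- compound 1 `CCCCCCCCCCCCCCCCOP(=O)(O)OCCSC(=S)N1CCCCCC1`: > 100000 nM, a limit
- compound 2 `CCCCCCCCCCCCCCCCOP(=O)(O)OCCSC(=S)N1CCN(C)CC1`: > 100000 nM, a limit

Compound 1 has no true number in this assay, and its value of > 100000 nM is only a limit. The same is true of compound 2, which gives > 100000 nM. Both compounds therefore sit at the limit of > 100000 nM in this assay, at which 2 of the 2 values shown sit.

The unmeasured compound 3 `CCCCCCOP(=O)(O)OCCSC(=S)N1CCCCCC1` keeps the core of compound 1 and changes only in its chain: hydrogen in place of decyl on a saturated chain carbon, six bonds along the chain from an oxygen on an unsaturated carbon. Going by the values given here, the one measured step, a step that the two limits leave unreadable from compound 1 to compound 2, lies at a different place in the molecule and has no readable size, so it offers no guide to the effect of losing the decyl. Among the compounds with values here, no measured step covers a change in this chain.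

The expectation therefore rests on compound 1, whose limit is > 100000 nM. Compound 3 is expected to stay weak in this assay, with no clear gain in strength, and the assay may again report only a limit. The expected step is a step that the limit leaves unreadable from compound 1 to compound 3, a rough estimate. For compound 3 the estimated value is 150000 nM, with an expected range of 60000 nM to 400000 nM.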

Compound 3, half-maximal inhibitory concentration: 17200 nM
Beside the measured number, compound 3's estimate is 8.7-fold (0.94 log units) above it; measured number below the stated range.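

Until now the data gave no number to work from, and the step between the two ring groups on the thiocarbonyl carbon cannot be read: the limit of > 100000 nM in this assay, at which 2 of the 3 values shown sit. Going by these compounds alone, the chain is the first place in these molecules where a change can be read, as hydrogen in place of decyl gives an at least 5.8-fold lower number from compound 1 to compound 3 (0.76 log units; beyond the scatter) in this assay. Within the data shown here, compound 3, with its shorter chain, is also the first compound here to give a true number, 17200 nM, so in this one pair the long chain of compound 1 is not needed for measurable inhibition, and the shorter chain goes with stronger inhibition.

Only two chain lengths are shown, both with the azepan-1-yl group, so it remains open whether a still shorter chain such as butyl, or a chain ending in an amine or a carboxylic acid, would push the number lower or raise it again. Going by these compounds, it is also open whether the same shortening would lower the number in a compound carrying the 4-methylpiperazin-1-yl group, where the long chain also leaves only a limit.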